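A few compounds are considered here, and "the series" means these few. Any claim that something is new, unique, unknown or untested is made for them only; others in the source may bear on it.

Notes on the series around compound 3 `O=C(NC1CC1)OC[C@H]1OC(n2cnc3c(NC4CCOC4)ncnc32)[C@H](O)[C@@H]1O`, which in an assay on DDT1 cells (Cricetulus griseus) for binding affinity to adenosine receptor A1 (Homo sapiens), read by radioligand binding (a higher number here means a weaker inhibitor, a lower number a stronger inhibitor), gives 209 nM. Compound 1 `CCCNC(=O)OC[C@H]1OC(n2cnc3c(NC4CCOC4)ncnc32)[C@H](O)[C@@H]1O` gives 235 nM in this assay, and compound 2 `CCCC/N=C(\S)OC[C@H]1OC(n2cnc3c(NC4CCOC4)ncnc32)[C@H](O)[C@@H]1O` gives 157 nM in this assay. Compound 3 sits between the other two, with a 1.1-fold lower number from compound 1 to compound 3 (0.05 log units; within the scatter) and a 1.3-fold higher number from compound 2 to compound 3 (0.12 log units; within the scatter), neither beyond the scatter, so the three numbers are effectively indistinguishable.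

Compound 4 `O[C@@H]1[C@@H](CO/C(S)=N/C2CCC2)OC(n2cnc3c(NC4CCOC4)ncnc32)[C@@H]1O` is not yet measured. Its change from compound 3: a group of 7 heavy atoms (5 carbon, 1 nitrogen, 1 sulfur; one four-membered non-aromatic ring of carbon only) in place of a group of 6 heavy atoms (4 carbon, 1 nitrogen, 1 oxygen; one three-membered non-aromatic ring of carbon only), on an oxygen on a saturated carbon. Among the compounds with values here, the nearest precedent is the step of a 1.5-fold lower number from compound 1 to compound 2 (0.18 log units; within the scatter), which likewise swaps a carbamoyl group for its sulfur-bearing counterpart carrying one more carbon; the step of a 1.3-fold higher number from compound 2 to compound 3 (0.12 log units; within the scatter) runs the opposite way and is equally small. Nothing in these three compounds has moved the number beyond the scatter. On this basis the estimated step is a 1.3-fold lower number from compound 3 to compound 4 (0.12 log units; within the scatter), with at most a slightly lower number expected and no movement beyond the scatter. Compound 4 is therefore expected to give 160 nM in this assay, in a range from 75 nM to 340 nM.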

Compound 4, inhibition constant: 148 nM
Compound 4: middle estimate off by 1.1-fold (0.03 log units), on the high side, and the stated range covers the measured number.
By their numbers in this assay, from the lowest: compounds 4, 2, 3 and 1 (each within the scatter of the next).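

Within the data shown here, at this position, on an oxygen on a saturated carbon, cyclobutyl in place of butyl on the double-bonded nitrogen gives the first ring-against-chain comparison in the sulfur-bearing group (a 1.1-fold lower number from compound 2 to compound 4 (0.03 log units; within the scatter)) in this assay, and it stays within the scatter. The two-part change of the sulfur-bearing group with a four-membered ring for the cyclopropylcarbamoyl group (a 1.4-fold lower number from compound 3 to compound 4 (0.15 log units; within the scatter)) and the wider change from the propyl carbamate (a 1.6-fold lower number from compound 1 to compound 4 (0.20 log units; within the scatter)) also stay within it, so all four compounds remain indistinguishable. No measurement here bears on why this position tolerates these changes.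

The oxygen-bearing cyclobutyl counterpart would separate ring size from the sulfur-bearing group, which the step from compound 3 to compound 4 changes together. Open too, as far as these compounds go, is whether a phenyl ring, a longer chain such as hexyl, or a carboxylic acid on this nitrogen would move the number beyond the scatter.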